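The source may hold more compounds than are shown below. What is called first, only, known or untested is meant among the compounds shown, and "the series" means these compounds.

In a functional assay on the whole organism for inhibition, with Rattus norvegicus as the target, read by paw edema, with stated times of 1 h and 3 h (on this read-out lower numbers stand for an effect already at smaller amounts and higher numbers for an effect only at larger amounts of compound), compound 1 `COC(=O)CO/N=C(\C)c1ccc(Cl)cc1` gives 24 mg/kg and compound 2 `C/C(=N\OCC(N)=O)c1ccc(Cl)cc1` gives 24 mg/kg with no change at the digits printed from compound 1 to compound 2 (within the scatter) between them. Compound 3 `C/C(=N\OCCC(=O)O)c1ccc(Cl)cc1` has the highest number of the three at 80 mg/kg and is reached by two modest steps (a 3.3-fold higher number from compound 1 to compound 3 (0.52 log units; beyond the scatter) and a 3.3-fold higher number from compound 2 to compound 3 (0.52 log units; beyond the scatter)). Compound 4 `C/C(=N\OCCCC(=O)O)c1ccc(Cl)cc1` differs from it by carboxymethyl in place of carboxy on a saturated chain carbon, two bonds along the chain from an oxygen with carboxymethyl in place of carboxy on a saturated chain carbon, two bonds along the chain from an oxygen. Among the compounds with values here, those two modest steps also replace the end group, so neither measures this change directly, and no measured pair isolates it. The expected result is no change at the digits printed from compound 3 to compound 4 (within the scatter) with no shift beyond the scatter. For compound 4 the estimate is 80 mg/kg within an expected range of 35 mg/kg to 180 mg/kg here.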

Compound 4, dose for half-maximal effect: 58 mg/kg
Compound 4: middle estimate off by 1.4-fold (0.14 log units), on the high side; measured number inside the range.
By their numbers in this assay, from the lowest: compounds 1 and 2 (each within the scatter of the next); then compounds 4 and 3 (each within the scatter of the next).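

In this assay, within the data shown here, the step from carboxymethyl to 2-carboxyethyl is the first to isolate chain length, and it gives a 1.4-fold lower number from compound 3 to compound 4 (0.14 log units; within the scatter), so this position takes the added carbon with no shift that can be told from scatter. The longer acid also stays apart from the ester and the amide, with a 2.4-fold higher number from compound 1 to compound 4 (0.38 log units; beyond the scatter) and a 2.4-fold higher number from compound 2 to compound 4 (0.38 log units; beyond the scatter), although each of these steps changes the end group as well as the length. Nothing measured here offers an explanation for these numbers.

From the compounds shown here alone, it remains open whether a methyl ester or a primary amide on the longer chain would behave as the shorter ones do. Going by these compounds, it is also open whether a still longer acid chain or an amine at the chain end would shift the number.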